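Butoxy for Benzyl on the Shared Core

The source may hold more compounds than are shown below. What is called first, only, known or untested is meant among the compounds shown, and "the series" means these compounds.

Of the compounds shown here, three built on the shared core have been measured so far. Compound 1 `O=C(Nc1ccc(Cc2ccccc2)cc1)Nc1nn(C(=O)Nc2ccc(Cc3ccccc3)cc2)c2ccccc12` carries a urea on the amine in addition to the aryl carbamoyl arm. In a functional assay on SW-620 cells (Homo sapiens) for inhibition, read by sulforhodamine B assay, with a stated time of 48 h (a higher number here means a weaker inhibitor of growth, a lower number a stronger inhibitor of growth), compound 1 reaches only the limit of > 100000 nM, which is a limit of the assay and not a number. Compound 3 `COc1ccc(NC(=O)Nc2n[nH]c3ccccc23)cc1` keeps the urea but lacks the carbamoyl arm, and in this assay compound 3 also sits at the limit of > 100000 nM. Among the compounds with values here, compound 2 `Nc1nn(C(=O)Nc2ccc(Cc3ccccc3)cc2)c2ccccc12` is the one member of the set that returns a number: in this assay compound 2 gives 3620 nM. Compound 2 therefore stands alone among the values shown, the other two being (the limit of > 100000 nM in this assay, at which 2 of the 3 values shown sit).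

Compound 4 `CCCCOc1ccc(NC(=O)n2nc(N)c3ccccc32)cc1` has not been measured. It differs from compound 2 by butoxy in place of benzyl on an aromatic carbon, in words butoxy in place of benzyl on an aromatic carbon. Within the data shown here, no measured pair in this set displays that change, so its size can only be expected, not read off. The author expects a 1.4-fold higher number from compound 2 to compound 4 (0.14 log units; within the scatter) in this assay, a step no larger than the usual scatter or leaning slightly toward weaker growth inhibition. Compound 4 is accordingly estimated at 5000 nM. The expected range for compound 4 runs from 1500 nM to 20000 nM.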

Compound 4, concentration for 50% growth inhibition: 18300 nM
For compound 4 the middle estimate is 3.7-fold (0.56 log units) below the measured one, within the range that was stated.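

In this assay, butoxy in place of benzyl on an aromatic carbon, para to a large group, gives a 5.1-fold higher number from compound 2 to compound 4 (0.70 log units; beyond the scatter), so the group at this position does change the read-out, by a step beyond the usual scatter. The ring of benzyl is nevertheless not needed for a measurable value, since compound 4, whose butoxy has no ring, still returns a number, although it is the weaker of this pair. Compound 4 thus joins compound 2 as a compound with a numerical value, while compound 1 and compound 3 remain at a limit of the assay, which is not a number: the limit of > 100000 nM in this assay, at which 2 of the 4 values shown sit.

This single pair changes the ring, the oxygen and the chain together, so it cannot show which of them carries the step, and a plain butyl chain, a phenoxy group or a longer chain such as hexyloxy at this position would be needed to separate them. The compounds shown also leave open whether the same change would give a step of similar size on a compound that also carries the urea on the amine, and they give no cause for the step.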